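Swapping a Long Chain Amide for a Short Enone

The source may hold more compounds than are shown below. What is called first, only, known or untested is meant among the compounds shown, and "the series" means these compounds.

In a functional assay on MCF7 cells (Homo sapiens) for antiproliferative activity, read by CCK-8 assay, with a stated time of 48 h (a higher number here means a weaker inhibitor, a lower number a stronger inhibitor), three compounds have been measured:
compound 1 `O=C(/C=C/CNCCOc1ccc(Oc2c(-c3ccc(F)cc3)sc3cc(O)ccc23)cc1)N1CCCCC1`: 16400 nM
compound 3 `CN(C)C(=O)/C=C/CN1CC(Oc2ccc(Oc3c(-c4ccc(F)cc4)sc4cc(O)ccc34)cc2)C1`: 22300 nM
Compound 2 `CNC(=O)/C=C/CN1CC(Oc2ccc(Oc3c(-c4ccc(F)cc4)sc4cc(O)ccc34)cc2)C1` reached only the limit of this assay, > 25000 nM.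

Compound 3 has the highest of the two numbers, though compound 1 sits within the usual scatter of it. Compound 4 `C/C=C/C(=O)N1CC(Oc2ccc(Oc3c(-c4ccc(F)cc4)sc4cc(O)ccc34)cc2)C1` differs from compound 3 by (prop-1-en-1-yl)carbonyl in place of 3-(dimethylcarbamoyl)prop-2-en-1-yl on an amine nitrogen in a ring. For the measured compounds named here, no measured step covers this change; the only one known, an at least 1.1-fold lower number from compound 2 to compound 3 (0.04 log units; that floor lies within the scatter), concerns a different position and stays within scatter. All three measured compounds are weak, one of them at the limit (the limit of > 25000 nM in this assay, at which 1 of the 3 values shown sits). No step beyond the scatter is therefore expected in this assay. Compound 4 is estimated at 20000 nM (range 8000 nM to 50000 nM), meaning a step of a 1.1-fold lower number from compound 3 to compound 4 (0.05 log units; within the scatter).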

Compound 4, half-maximal inhibitory concentration: 28000 nM
Compound 4: middle estimate off by 1.4-fold (0.15 log units), on the low side; measured number inside the range.
By their numbers in this assay, from the lowest: compounds 1, 3 and 4 (each within the scatter of the next).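

In this assay, putting (prop-1-en-1-yl)carbonyl in place of 3-(dimethylcarbamoyl)prop-2-en-1-yl on the amine nitrogen of the four-membered ring gives a 1.3-fold higher number from compound 3 to compound 4 (0.10 log units; within the scatter) and so no readable change. The earlier step altered only one methyl on the amide nitrogen, whereas this one replaces the whole group and the numbers still stay in the same weak range. Compound 2 stands at a limit, so its step to compound 4 cannot be read: the limit of > 25000 nM in this assay, at which 1 of the 4 values shown sits.

As far as these compounds go, whether a longer chain ending in a carboxylic acid or a primary amine on this nitrogen would move the number beyond the scatter remains open.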